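Methyl for hydrogen on the second aryl ring

A few compounds are considered here, and "the series" means these few. Any claim that something is new, unique, unknown or untested is made for them only; others in the source may bear on it.

Values in a functional assay on the whole organism for inhibition, with Mus musculus as the target, with a stated time of 1 h, at a dose of 50 mg/kg by the oral route (on this read-out higher numbers stand for more inhibition at the one dose given (going by the name of the read-out) and lower numbers for less inhibition), for the three compounds measured so far:
compound 1, `O=S(=O)(c1ccccc1)c1cnc2cc(-c3ccc(Cl)cc3)nn2c1-c1ccc(Br)cc1`: 24.2%
compound 2, `Cc1ccc(-c2c(S(=O)(=O)c3ccccc3)cnc3c(Br)c(-c4ccccc4)nn23)cc1`: 65.5%
compound 3, `Cc1ccc(-c2c(S(=O)(=O)c3ccccc3)cnc3cc(-c4ccccc4)nn23)cc1`: 42.5%

Compound 3 stands second highest of the three numbers. Compound 1 lies lower than compound 3 beyond the scatter, and compound 2 lies higher than compound 3 beyond the scatter. Among the measured compounds shown here, the one step between compounds that differ in a single place is the change from compound 2 to compound 3, hydrogen in place of bromo on an aromatic carbon, which gave a number 23 percentage points lower from compound 2 to compound 3 (beyond the scatter). For the measured compounds named here, compound 1 and compound 3 differ in two places, so their two values show only that compound 1 is the lower of the pair.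

The next compound, compound 4, `Cc1ccc(-c2cc3ncc(S(=O)(=O)c4ccccc4)c(-c4ccc(C)cc4)n3n2)cc1`, differs from compound 3 by methyl in place of hydrogen on an aromatic carbon. Going by the values given here, no measured step touches this change: the only step on record concerns bromo on the core, not a methyl on the aryl ring. Nothing in the three values therefore points in either direction for a methyl at this place. Compound 4 is expected to give 43%, with a range of 25% to 62%. The estimated step is a number 0.5 percentage points higher from compound 3 to compound 4 (within the scatter), within the scatter.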

Compound 4, a percentage reported as inhibition, in the whole organism at one dose (the size of the read-out at that dose, not a potency): 54.6%
Compound 4: middle estimate off by 11.6 percentage points, on the low side, and the stated range covers the measured number.
By their numbers in this assay, from the lowest: compound 1; then compound 3; then compound 4; then compound 2.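

In this assay the change from phenyl to 4-methylphenyl gives a number 12.1 percentage points higher from compound 3 to compound 4 (beyond the scatter) and so shows that this place, para to a large group, is not silent: one added methyl moves the read-out beyond the scatter. Among the compounds shown here, until now the only one-place step on record lay on the core, namely a number 23 percentage points lower from compound 2 to compound 3 (beyond the scatter), so the series now has a second place where a single change shifts inhibition at the one dose given, and this one lies on an aryl ring. No measurement at hand bears on what lies behind the higher number for the methyl compound.

Going by these compounds, what remains open is whether this rise is particular to methyl or would also appear with an ethyl, a methoxy, an amine or a carboxylic acid at the same place, since one substituent on one ring gives no trend. On these data alone, it is also open whether the methyl step would hold on a core carrying the bromo, and, as the read-out is a single oral dose at a single time, whether the step reflects potency at all.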